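A few compounds are considered here, and "the series" means these few. Any claim that something is new, unique, unknown or untested is made for them only; others in the source may bear on it.

For the measured compounds named here, in a physicochemical assay for solubility, in phosphate buffer, at pH 7.4 (a lower number here means a less soluble compound, a higher number a more soluble compound), compound 3 (`COCC1CCN(c2nccnc2OC2CN(c3ccc4ccccc4n3)C2)CC1`) gives 53000 nM, the middle of the three numbers so far. Compound 2 (`OCC1CCN(c2cccnc2OC2CN(c3ccc4ccccc4n3)C2)CC1`) gives 189000 nM and compound 1 (`OCC1CCN(c2nccnc2Oc2ccc(Nc3nc4ccccc4s3)cc2)CC1`) gives 6000 nM, and compound 3 differs from each of them beyond the usual scatter.

The next structure is compound 4 (`N#Cc1ccc(-c2nccnc2OC2CN(c3ccc4ccccc4n3)C2)cc1`), with 4-cyanophenyl in place of 4-(methoxymethyl)piperidin-1-yl on an aromatic carbon, next to the ring nitrogen: 4-cyanophenyl in place of 4-(methoxymethyl)piperidin-1-yl on an aromatic carbon.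

Going by the values given here, no measured pair differs in one place only, so there is no direct precedent for this change. Among the compounds with values here, the only guide is indirect: among the measured compounds, the one with a further aromatic ring, compound 1 at 6000 nM, holds the lowest number. On that thin basis, a moderate fall beyond the scatter is expected in this assay, and the estimated step is a 4.4-fold lower number from compound 3 to compound 4 (0.65 log units; beyond the scatter). For compound 4 the estimated value is 12000 nM, with an expected range of 2500 nM to 45000 nM.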

Compound 4, solubility: < 1000 nM
Compound 4 gave a limit, no number (the forecaster's own chance of this, stated with the estimate: 10%); at least 12-fold (1.07 log units) between middle value and limit.
By their numbers in this assay, from the lowest: compound 1; then compound 3; then compound 2. At a limit, below all of these: compound 4.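

In this assay compound 4 gives < 1000 nM, which is a limit and not a number: the limit of < 1000 nM in this assay, at which 1 of the 4 values shown sits.

For the compounds shown here, this gives the first reading of a single change at this position, on an aromatic carbon of a six-membered aromatic ring with 2 nitrogen, next to the ring nitrogen: 4-cyanophenyl in place of 4-(methoxymethyl)piperidin-1-yl gives an at least 53-fold lower number from compound 3 to compound 4 (1.72 log units; beyond the scatter). The group at this position can therefore move the read-out by a large step, though the full size of that step cannot be read from a limit.

The change swaps the non-aromatic ring for an aromatic ring and brings in the nitrile at once, so the two stay unseparated. Open, on these data alone, is where an unsubstituted phenyl, or a phenyl carrying an amine or a carboxylic acid in place of the nitrile, would fall in this assay.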